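This account rests on a few compounds, and the source may have more. Where it says the series, first, only, none or still open, it means among the compounds named here.

Measured compounds and values in a functional assay (muscle tissue) with Cavia porcellus as the target; a higher number here means that more compound is needed for the effect, a lower number that less compound is needed:
- compound 1 `COC(=O)C1=C(C)N=C(C)/C(=C(\O)OC)C1c1ccc(Cl)cc1`: 8130 nM
- compound 2 `COC(=O)C1=C(C)N=C(C)/C(=C(\O)OC)C1c1ccc(Cl)cc1Cl`: 640 nM
- compound 3 `COC(=O)C1=C(C)N=C(C)/C(=C(\O)OC)C1c1ccc(C#N)cc1`: 3470 nM

Compound 3 stands second highest of the three numbers in this assay. Its nearest neighbour is compound 1, with a 2.3-fold lower number from compound 1 to compound 3 (0.37 log units; beyond the scatter); its furthest is compound 2, with a 5.4-fold higher number from compound 2 to compound 3 (0.73 log units; beyond the scatter). Within the data shown here, the one change that most moves the numbers in this set is the step from compound 1 to compound 2, a 13-fold lower number from compound 1 to compound 2 (1.10 log units; beyond the scatter), chloro in place of hydrogen on an aromatic carbon.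

Compound 4 `COC(=O)C1=C(C)N=C(C)/C(=C(\O)OC)C1c1ccccc1F` is the next compound to be measured in this assay. Relative to compound 3 the change is 2-fluorophenyl in place of 4-cyanophenyl on a saturated ring carbon. Two of the measured steps bear on this: the step from compound 1 to compound 2 shows that a second halogen on the aromatic ring brings a large gain, while the step from compound 1 to compound 3 shows the cyano group itself is worth only a modest gain over chloro. Among the measured compounds shown here, the new compound gives up the cyano group but gains a fluorine; on balance a modest step toward a lower number is expected, a 2.3-fold lower number from compound 3 to compound 4 (0.36 log units; beyond the scatter), with wide uncertainty since no measured pair carries a fluorine or lacks the para substituent. Compound 4 is therefore estimated at 1500 nM, within 400 nM to 6000 nM.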

Compound 4, half-maximal effective concentration: 42.7 nM
Beside the measured number, compound 4's estimate is 35-fold (1.55 log units) above it; the whole stated range lies above it.
By their numbers in this assay, from the lowest: compound 4; then compound 2; then compound 3; then compound 1.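

In this assay, the group on the saturated ring carbon spans a much wider range than the first three compounds showed: 2-fluorophenyl gives an 81-fold lower number from compound 3 to compound 4 (1.91 log units; beyond the scatter), a 15-fold lower number from compound 2 to compound 4 (1.18 log units; beyond the scatter) and a 190-fold lower number from compound 1 to compound 4 (2.28 log units; beyond the scatter), so compound 4 now holds the lowest number of the four. A chloro or cyano group at the 4 position of the phenyl ring is therefore not required for a low number here, as compound 4 carries no group there and still lies below all three compounds that do; the two lowest numbers belong to compound 4 and compound 2, the only compounds with a halogen at the 2 position of that ring, and none of the four goes against this. (No measurement at hand accounts for the size of these steps)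

Compound 4 differs from each earlier compound both in the halogen and in the group at the 4 position, so the shares of the fluorine and of the empty 4 position cannot be separated. Plain phenyl, 2-chlorophenyl and 4-fluorophenyl would divide those contributions, and 2-methoxyphenyl or 2-aminophenyl would test whether a group other than a halogen at the 2 position gives a similarly low number.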